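The source may report more compounds than this note shows. Statements on the series, on what has been measured and on what is new or still open speak of the compounds shown alone.

Of the compounds shown here, two with a shared core have been measured in an assay on brain for displacement of a labelled ligand from Neuronal acetylcholine receptor; alpha4/beta2 (Rattus norvegicus); on this read-out lower numbers stand for stronger inhibition and higher numbers for weaker inhibition. Compound 1, `C[N+]1(C)C[C@H]2C[C@@H]1CN2c1ccc(-c2ccccc2)nn1`, gives 5500 nM in this assay. Compound 2, `c1ccc(-c2ccc(N3C[C@@H]4C[C@H]3CN4)nn2)cc1`, gives 31200 nM in this assay, the highest of the two numbers and therefore the weaker binder of the pair; its number is well beyond the usual scatter from that of compound 1. The shared core carries a six-membered aromatic ring with two nitrogen atoms, and the next compound changes what sits on that ring. Compound 3, `Clc1ccc(N2C[C@@H]3C[C@H]2CN3)nn1`, differs from compound 2 in one place: chloro in place of phenyl on an aromatic carbon, on an aromatic carbon next to the ring nitrogen. Going by the values given here, no measured pair shows what this change does, so the expectation rests on the structures alone; a step of moderate size toward stronger binding, a 39-fold lower number from compound 2 to compound 3 (1.59 log units; beyond the scatter), is expected, with a wide margin. Compound 3 is estimated to give 800 nM in this assay, between 100 nM and 6000 nM.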

Compound 3, inhibition constant: 6 nM
The estimate for compound 3 lay 130-fold (2.12 log units) above the measured number; the whole stated range lies above it.
By their numbers in this assay, from the lowest: compound 3; then compound 1; then compound 2.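

At this aromatic carbon next to the ring nitrogen, chloro in place of phenyl gives a 5200-fold lower number from compound 2 to compound 3 (3.72 log units; beyond the scatter) in this assay and is one of the largest changes a single swap can bring. Both earlier compounds carry phenyl here, so they could not show how much binding depends on the group at this position, or that phenyl is far from the best choice among the two groups compared. Nothing available explains why the step is so large.

The pair also cannot separate the loss of phenyl from the gain of chloro, since a plain hydrogen at this carbon does not appear among the compounds shown. From the compounds shown here alone, whether fluoro, bromo, methyl, methoxy or an amine would bind as well as chloro also remains open.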